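The source may hold more compounds than are shown below. What is called first, only, known or untested is meant among the compounds shown, and "the series" means these compounds.

In a functional assay on A549 cells (Homo sapiens) for inhibition, read by MTT assay (a lower number here means a stronger inhibitor, a higher number a weaker inhibitor), three analogues sharing one core have been measured. Compound 1 `CCCCCCCCCCn1cc(/C=C/C(=O)c2ccc(NC(=O)CN3CCN(c4ccccc4)CC3)cc2)nn1` gives 52100 nM. Compound 2 `CCCCCCCCCCn1cc(/C=C/C(=O)c2ccc(NC(=O)CN3CCN(C(=O)OC(C)(C)C)CC3)cc2)nn1` gives 45400 nM. Compound 3 `CCCCCCCCCCn1cc(/C=C/C(=O)c2ccc(NC(=O)CN3CCN(c4ccccc4F)CC3)cc2)nn1` gives 57000 nM. Compound 3 is separated from each of the others by no more than the scatter: the step of a 1.1-fold higher number from compound 1 to compound 3 (0.04 log units; within the scatter) and the step of a 1.3-fold higher number from compound 2 to compound 3 (0.10 log units; within the scatter) both lie within it, as does the step of a 1.1-fold lower number from compound 1 to compound 2 (0.06 log units; within the scatter) between the other two.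

Compound 4 `CCCCCCCCCCn1cc(/C=C/C(=O)c2ccc(NC(=O)CN3CCN(c4ccccc4OC)CC3)cc2)nn1` differs from compound 3 by one change: methoxy in place of fluoro on an aromatic carbon. The measured steps that bear on this position are the step from compound 1 to compound 3, which placed a fluoro on this same aromatic carbon, and the step from compound 2 to compound 3, which exchanged the whole group on the amine nitrogen in the ring; neither moved the number beyond the scatter. Exchanging fluoro for methoxy at the same place is therefore expected to give no step beyond the scatter in this assay, in either direction. Compound 4 is estimated at 55000 nM, with a range from 27000 nM to 110000 nM, which means an expected step of a 1.0-fold lower number from compound 3 to compound 4 (0.02 log units; within the scatter).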

Compound 4, half-maximal inhibitory concentration: 62500 nM
Compound 4: middle estimate off by 1.1-fold (0.06 log units), on the low side; the range from low to high includes it.
By their numbers in this assay, from the lowest: compounds 2, 1, 3 and 4 (each within the scatter of the next).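

In this assay, methoxy is a second substituent on this aromatic carbon, ortho to a large group, and it too leaves the number within the scatter: the exchange for fluoro gives a 1.1-fold higher number from compound 3 to compound 4 (0.04 log units; within the scatter), and the exchange for hydrogen gives a 1.2-fold higher number from compound 1 to compound 4 (0.08 log units; within the scatter). The hydrogen-bond acceptor counted for methoxy therefore brings no step beyond the scatter here, and replacing the whole tert-butoxycarbonyl group with 2-methoxyphenyl gives only a 1.4-fold higher number from compound 2 to compound 4 (0.14 log units; within the scatter). Nothing available gives a cause for these results.

The compounds shown leave open whether an amine or a carboxylic acid on this aromatic carbon would move the number beyond the scatter. They also leave open whether any change on this ring matters once the decyl chain is replaced by a shorter chain.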